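Compound 3 to compound 4: losing the non-aromatic ring

This account rests on a few compounds, and the source may have more. Where it says the series, first, only, none or still open, it means among the compounds named here.

Values in a functional assay on NCI-H1581 cells (Homo sapiens) for antiproliferative activity, read by CCK-8 assay, with a stated time of 72 h; a lower number here means a stronger inhibitor, a higher number a weaker inhibitor:
- Compound 1 `COc1cc(OC)c(Cl)c(-c2ccc3c(NC(=O)c4ccc(N5CCCN(C)CC5)cc4)n[nH]c3n2)c1Cl`: 1.3 nM
- Compound 2 `COc1cc(OC)c(Cl)c(-c2ccc3c(NC(=O)c4ccc(N5CCN(C(C)C)CC5)cc4)n[nH]c3n2)c1Cl`: 1.4 nM
- Compound 3 `COc1cc(OC)c(Cl)c(-c2ccc3c(NC(=O)c4ccc(N5CCN(C)CC5)s4)n[nH]c3n2)c1Cl`: 3.7 nM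

Compound 3 stands highest of the three, beyond the scatter from both others. Compound 4 `COc1cc(OC)c(Cl)c(-c2ccc3c(NC(=O)c4ccc(N)cc4)n[nH]c3n2)c1Cl` is still unmeasured in this assay. The structural change is a group of 7 heavy atoms (6 carbon, 1 nitrogen; one six-membered aromatic ring of carbon only) in place of a group of 12 heavy atoms (9 carbon, 2 nitrogen, 1 sulfur; one five-membered aromatic ring with 1 hetero atom, one six-membered non-aromatic ring with 2 hetero atoms), on a carbonyl carbon, with 4-aminophenyl entering on a carbonyl carbon. Among the measured compounds shown here, the only measured step, a 1.1-fold higher number from compound 1 to compound 2 (0.03 log units; within the scatter), swaps 4-methyl-1,4-diazepan-1-yl for 4-isopropylpiperazin-1-yl and stays within the scatter. It bears only weakly, since every measured compound keeps a non-aromatic ring and compound 4 has none. On thin evidence, a weaker result is therefore expected, with an estimated step of a 5.4-fold higher number from compound 3 to compound 4 (0.73 log units; beyond the scatter). For compound 4 the estimated value is 20 nM, with an expected range of 4 nM to 120 nM.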

Compound 4, half-maximal inhibitory concentration: 218 nM
Compound 4: the middle estimate sits 11-fold (1.04 log units) below what was measured, and the stated range ends below it.
By their numbers in this assay, from the lowest: compounds 1 and 2 (each within the scatter of the next); then compound 3; then compound 4.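

In this assay, amino in place of 4-isopropylpiperazin-1-yl on the aromatic carbon gives a 160-fold higher number from compound 2 to compound 4 (2.19 log units; beyond the scatter) and amino in place of 4-methyl-1,4-diazepan-1-yl gives a 170-fold higher number from compound 1 to compound 4 (2.22 log units; beyond the scatter) as the two large steps, so the earlier swap of one non-aromatic ring for another gave no sign of how much rests on having such a ring here. The step of a 59-fold higher number from compound 3 to compound 4 (1.77 log units; beyond the scatter) is also large, but it changes the five-membered aromatic ring as well and cannot be assigned to the non-aromatic ring alone. No measurement bears on the cause of these steps.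

Going by these compounds, whether the ring itself matters or only a substituted amine remains open. A dimethylamino or morpholin-4-yl group on the same aromatic carbon would separate the two.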